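The compounds below may be only part of what the source reports. "The series", "measured", "known", "first", "only" and "open" are said of these compounds alone.

Compound 1 `CC(=O)N1CCC(C(=O)N(CCCN2CCC(CNC(=O)c3cnccn3)CC2)c2ccc(C)c(Cl)c2)CC1` and compound 2 `CC(=O)N1CCC(C(=O)N(CCCN2CCN(Cc3ccc(S(C)(=O)=O)cc3)CC2)c2ccc(C)c(Cl)c2)CC1` have both been measured in an ADME assay (Homo sapiens) for cytotoxicity; a lower number here means that less compound is tolerated, a higher number that more compound is tolerated. Compound 1 reaches only the limit of the assay, > 52400 nM. Compound 2 likewise reaches only the limit, > 49200 nM. Both values are limits (the limit of > 49200 nM in this assay, at which 1 of the 2 values shown sits, (the limit of > 52400 nM in this assay, at which 1 of the 2 values shown sits)), so compound 2 stands at the top of what this assay can report, alongside compound 1. Compound 3 `CC(=O)N1CCC(C(=O)N(CCCN2CCN(Cc3cccnc3)CC2)c2ccc(C)c(Cl)c2)CC1` differs from compound 2 by pyridin-3-yl in place of 4-(methylsulfonyl)phenyl on a saturated chain carbon bound to an amine nitrogen in a ring. Among the compounds with values here, no measured step exists to guide this change, so no shift beyond the scatter is expected in this assay. Compound 3 is therefore expected to give 50000 nM, between 20000 nM and 100000 nM, most likely again as a limit. The expected step that the limit leaves unreadable from compound 2 to compound 3 is accordingly small.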

Compound 3, half-maximal cytotoxic concentration: > 56700 nM
Compound 3 was reported as a limit; the forecaster's own chance of this, stated with the estimate: 85%; at least 1.1-fold (0.05 log units) between middle value and limit.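

In this assay, compound 2 and compound 3 are both reported only as limits, so the step between them cannot be read. The compounds shown leave open at what concentration any of them becomes cytotoxic.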